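A methoxy for fluoro exchange on the shared core

This account rests on a few compounds, and the source may have more. Where it says the series, first, only, none or still open, it means among the compounds named here.

Compound 1 `O=C(Nc1nc2ccc(F)cc2s1)c1cn(-c2ccccc2)nc1-c1ccccc1` is the parent of the set. In an ADME assay on HEK-293T cells (Homo sapiens) for cytotoxicity, read by MTT assay, with a stated time of 72 h (a higher number here means a weaker inhibitor, a lower number a stronger inhibitor), compound 1 gives 17600 nM. Compound 3 `O=C(Nc1nc2ccc(F)cc2s1)c1cn(-c2ccccc2)nc1-c1ccc(F)cc1` adds a second fluoro, and in this assay compound 3 gives 16700 nM, standing together with compound 1 since the gap between them, a 1.1-fold lower number from compound 1 to compound 3 (0.02 log units; within the scatter), is within the scatter. Compound 2 `COc1ccc2nc(NC(=O)c3cn(-c4ccccc4)nc3-c3ccccc3)sc2c1` carries a methoxy in place of the first fluoro. In this assay compound 2 reaches only the limit of the assay, > 50000 nM, and no number is known for it. The step of an at least 2.8-fold higher number from compound 1 to compound 2 (0.45 log units; beyond the scatter) is therefore known only as a lower bound, since it rests on (the limit of > 50000 nM in this assay, at which 1 of the 3 values shown sits).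

Compound 4 `COc1ccc2nc(NC(=O)c3cn(-c4ccccc4)nc3-c3ccc(F)cc3)sc2c1` differs from compound 3 in one place: methoxy in place of fluoro on an aromatic carbon. This is the same exchange that separates compound 1 from compound 2, where the number rose beyond the scatter, so an upward step of at least that size is expected from compound 3 to compound 4, a 3.3-fold higher number from compound 3 to compound 4 (0.52 log units; beyond the scatter). Compound 4 is accordingly expected in this assay to give about 55000 nM, between 25000 nM and 130000 nM, and quite possibly only a limit rather than a number.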

Compound 4, half-maximal inhibitory concentration: > 50000 nM
Compound 4 was reported as a limit; the forecaster's own chance of this, stated with the estimate: 65%; the middle value does not contradict the limit.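

In this assay, the exchange of fluoro for methoxy on the aromatic carbon now gives an at least 2.9-fold higher number from compound 3 to compound 4 (0.47 log units; beyond the scatter). Until now this rise had been seen on the core of compound 1 alone, and it now recurs on the core of compound 3, which carries the second fluoro, so the direction of the change holds on both cores shown: the same change on two cores in this assay, an at least 2.8-fold higher number (0.45 log units; beyond the scatter) from compound 1 to compound 2 and an at least 2.9-fold higher number (0.47 log units; beyond the scatter) from compound 3 to compound 4; the limit leaves it open whether they differ The step that adds the second fluoro to the methoxy compounds, from compound 2 to compound 4, cannot be read because both ends of it sit at the limit of the assay: the limit of > 50000 nM in this assay, at which 2 of the 4 values shown sit.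

As far as these compounds go, the true size of the exchange on either core remains open, as does the question of whether it differs between them, since compound 2 and compound 4 are each known only as a limit. Also open, from the compounds shown here alone, is whether the rise belongs to methoxy in particular or would also appear with another group on this aromatic carbon, such as an amine, a hydroxyl or a longer chain like ethoxy.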